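The source may report more compounds than this note shows. Statements on the series, on what has been measured and on what is new or still open speak of the compounds shown alone.

In an ADME assay on HepG2 cells (Homo sapiens) for cytotoxicity (on this read-out higher numbers stand for lower toxicity in this test and lower numbers for higher toxicity in this test), compound 1 `CN1CCN(CC#Cc2cc3ncnc(Nc4ccc(OCc5cccc(F)c5)c(Cl)c4)c3s2)CC1` gives 11 uM. Compound 2 `CN(C)CC#Cc1cc2ncnc(Nc3ccc(OCc4cccc(F)c4)c(Cl)c3)c2s1` gives > 32 uM, which is a limit of the assay and not a number. Compound 3 `Fc1cccc(COc2ccc(Nc3ncnc4cc(C#CCN5CCCC5)sc34)cc2Cl)c1` gives 4.9 uM, the lowest number of the set. Compound 4 `Fc1cccc(COc2ccc(Nc3ncnc4cc(C#CC5CCCC5)sc34)cc2Cl)c1` has cyclopentyl in place of (pyrrolidin-1-yl)methyl on a triple-bonded carbon. The nearest evidence comes from swaps of one amine for another: an at least 2.9-fold higher number from compound 1 to compound 2 (0.46 log units; beyond the scatter), a 2.2-fold lower number from compound 1 to compound 3 (0.35 log units; beyond the scatter) and an at least 6.5-fold lower number from compound 2 to compound 3 (0.81 log units; beyond the scatter). All lie beyond the scatter, so changes at this place can move the number, but none removes the nitrogen. With compound 3 lowest at 4.9 uM, a modest rise is the likelier outcome. The expected step is a 2.2-fold higher number from compound 3 to compound 4 (0.35 log units; beyond the scatter). Compound 4 is estimated at 11 uM, within an expected range from 4 uM to 32 uM.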

Compound 4, half-maximal toxic concentration: > 31 uM
Compound 4: no number, only a limit; the forecaster's own chance of this, stated with the estimate: 30%; middle value at least 2.8-fold (0.44 log units) from the limit.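

Cyclopentyl is the first group at this place that carries no nitrogen, and it gives an at least 6.3-fold higher number from compound 3 to compound 4 (0.80 log units; beyond the scatter) and an at least 2.8-fold higher number from compound 1 to compound 4 (0.44 log units; beyond the scatter). The value of compound 4 is a limit of the assay and not a number. Compound 2 keeps an amine on this chain and gives > 32 uM, also a limit, so an amine here does not always go with a low number.

The step from compound 2 to compound 4 cannot be read, since both values are limits. Still open, from the compounds shown here alone, is how a morpholin-4-yl group or a longer carbon chain would behave at this place.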